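The source may report more compounds than this note shows. Statements on the series, on what has been measured and on what is new or still open speak of the compounds shown alone.

Compound 1 `CCOc1ccc(NS(=O)(=O)c2ccc(C)cc2)c2cn[nH]c12` was measured in a functional assay on A549 cells (Homo sapiens) for cytotoxicity, read by MTT assay, with a stated time of 72 h (on this read-out lower numbers stand for stronger inhibition and higher numbers for weaker inhibition), where compound 1 gives 58500 nM. Among the compounds with values here, of the two numbers known so far, this is the highest; its nearest neighbour is compound 2 `CCOc1ccc(NS(=O)(=O)c2ccc(C)cc2)c2c(Br)n[nH]c12`, which in this assay gives 17500 nM. Within the data shown here, the one change measured so far is a 3.3-fold lower number from compound 1 to compound 2 (0.52 log units; beyond the scatter), a bromo in place of hydrogen on an aromatic carbon of the shared core. Compound 3 `C=CCn1ncc2c(NS(=O)(=O)c3ccc(C)cc3)ccc(OCC)c21` differs from compound 1 in a different way: allyl in place of hydrogen on an aromatic nitrogen. Among the measured compounds shown here, no measured step touches the ring nitrogen, so the bromo step cannot be carried over to this change, and it gives no direction for it. With nothing bearing directly on an allyl at this place, no step beyond the scatter is expected in this assay. The estimated step is therefore a 1.2-fold lower number from compound 1 to compound 3 (0.07 log units; within the scatter). For compound 3 the expected value is 50000 nM, within a range of 15000 nM to 160000 nM.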

Compound 3, half-maximal inhibitory concentration: 100000 nM
For compound 3 the middle estimate is 2.0-fold (0.30 log units) below the measured one, and the stated range covers the measured number.
By their numbers in this assay, from the lowest: compound 2; then compounds 1 and 3 (each within the scatter of the next).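

In this assay the allyl in place of hydrogen on an aromatic nitrogen gives a 1.7-fold higher number from compound 1 to compound 3 (0.23 log units; within the scatter) and so leaves compound 3 within the scatter of compound 1. At this ring nitrogen, then, the shown change does not separate the two compounds on this read-out, whereas the bromo on the aromatic carbon gives a 3.3-fold lower number from compound 1 to compound 2 (0.52 log units; beyond the scatter) and remains the only step here beyond the scatter. No measurement is available that would account for the outcome at either place.

As far as these compounds go, whether in this assay a longer alkyl chain, a benzyl or a carboxylic acid on this same nitrogen would give a step beyond the scatter stays open. So does whether the allyl and the bromo together on the shared core would give the number seen with the bromo alone.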